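Bromo for chloro on the pendant phenyl of compound 3

This account rests on a few compounds, and the source may have more. Where it says the series, first, only, none or still open, it means among the compounds named here.

Measured so far:
compound 1 `Brc1cn2ccnc2c(-c2ccc3ncn(C4CCCCC4)c3c2)n1`: 9.36%
compound 2 `Fc1ccc(-c2cn3ccnc3c(-c3ccc4ncn(C5CCCCC5)c4c3)n2)cc1`: 12.8%
compound 3 `Clc1ccc(-c2cn3ccnc3c(-c3ccc4ncn(C5CCCCC5)c4c3)n2)cc1`: 11.6%

In a functional assay on A549 cells (Homo sapiens) for inhibition, read by sulforhodamine B assay, with a stated time of 48 h, tested at 10 uM (a lower number here means less inhibition, a higher number more inhibition at the concentration tested (going by the name of the read-out)), compound 3 stands second highest of the three numbers. Its nearest neighbour is compound 2, with a number 1.2 percentage points lower from compound 2 to compound 3 (within the scatter); its furthest is compound 1, with a number 2.2 percentage points higher from compound 1 to compound 3 (within the scatter). The whole measured spread sits inside the scatter, so no order among compounds 1, 2 and 3 can be read from these numbers.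

Compound 4 `Brc1ccc(-c2cn3ccnc3c(-c3ccc4ncn(C5CCCCC5)c4c3)n2)cc1` is the next member. It differs from compound 3 in one place: bromo in place of chloro on an aromatic carbon. The step that bears most directly on it is the halogen exchange from compound 2 to compound 3, a number 1.2 percentage points lower from compound 2 to compound 3 (within the scatter), which stayed within the scatter. The two steps from compound 1, a number 3.4 percentage points higher from compound 1 to compound 2 (within the scatter) and a number 2.2 percentage points higher from compound 1 to compound 3 (within the scatter), replace bromo by a 4-fluorophenyl or a 4-chlorophenyl and also stayed within the scatter. Nothing here suggests that a further halogen exchange on the same ring would move this assay beyond its scatter.

For compound 4 the expected step is therefore a number 0.1 percentage points lower from compound 3 to compound 4 (within the scatter), essentially none. The estimate for compound 4 is 11.5%, with a range from 3% to 21%.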

Compound 4, a percentage reported as inhibition, at one concentration (the size of the read-out at that concentration, not a potency): 15.3%
Compound 4: the middle estimate sits 3.8 percentage points below what was measured; measured number inside the range.
By their numbers in this assay, from the lowest: compounds 1, 3, 2 and 4 (each within the scatter of the next).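

Replacing fluoro or chloro with bromo, on an aromatic carbon para to a large group, extends the halogen exchange at this place to a third member in this assay: bromo in place of chloro gives a number 3.7 percentage points higher from compound 3 to compound 4 (within the scatter), and bromo in place of fluoro gives a number 2.5 percentage points higher from compound 2 to compound 4 (within the scatter), so the three halogens cannot be told apart here. The larger change, which swaps the bare bromo for the whole pendant ring, gives a number 5.9 percentage points higher from compound 1 to compound 4 (within the scatter), so this pendant ring with a bromo on it also cannot be separated from the simple bromo compound, as was already the case for its fluoro and chloro counterparts. No evidence beyond these percentages bears on this result.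

From the compounds shown here alone, whether an amine, a carboxylic acid or a methoxy group at the same place on the phenyl ring would move this assay beyond its scatter remains open. Each number is also a read-out at a single concentration, so the potency of these compounds remains open as well.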